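The source may report more compounds than this note shows. Statements on the series, on what has been measured and on what is new or still open speak of the compounds shown alone.

In a functional assay on MCF7 cells (Homo sapiens) for inhibition, read by trypan blue exclusion, with a stated time of 3 days (a lower number here means a stronger inhibitor, a higher number a weaker inhibitor), three compounds built on a shared core have been measured so far. Compound 1 `COc1cc(C(=O)c2cn(-c3ccccc3)cc2-c2cccc(C)c2)cc(OC)c1OC` gives 450 nM, compound 2 `COc1cc(C(=O)c2cn(-c3ccccc3)cc2-c2ccc(C)cc2)cc(OC)c1OC` gives 280 nM, and compound 3 `COc1cc(C(=O)c2cn(-c3ccccc3F)cc2-c2ccccc2)cc(OC)c1OC` gives 85 nM. Compound 3 therefore has the lowest number of the three, and its gap to each of the others lies beyond the scatter. The unmeasured compound 4 `COc1cc(C(=O)c2cn(-c3cccc(N)c3)cc2-c2ccccc2)cc(OC)c1OC` differs from compound 3 in one group, with 3-aminophenyl in place of 2-fluorophenyl on an aromatic nitrogen. Among the measured compounds shown here, the only measured step between close relatives, a 1.6-fold lower number from compound 1 to compound 2 (0.21 log units; within the scatter), lies within the scatter. It swaps 3-methylphenyl for 4-methylphenyl on an aromatic carbon, so it says little about a change on the nitrogen. For the measured compounds named here, no measured step alters the group on that nitrogen, which leaves the data without a firm direction, and no step beyond the scatter is expected in this assay. The expected step, a 1.4-fold lower number from compound 3 to compound 4 (0.15 log units; within the scatter), is an uncertain estimate. For compound 4 the estimated value is 60 nM, with an expected range from 14 nM to 260 nM.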

Compound 4, half-maximal inhibitory concentration: 74 nM
Beside the measured number, compound 4's estimate is 1.2-fold (0.09 log units) below it, within the range that was stated.
By their numbers in this assay, from the lowest: compounds 4 and 3 (each within the scatter of the next); then compounds 2 and 1 (each within the scatter of the next).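

In this assay, the group on the aromatic nitrogen can be changed from 2-fluorophenyl to 3-aminophenyl with only a 1.1-fold lower number from compound 3 to compound 4 (0.06 log units; within the scatter), which lies within the scatter. Among the compounds shown here, this is the first reading at this position, and it shows that a phenyl group with a fluorine can give way to one with an amine, which adds a hydrogen-bond donor and a hydrogen-bond acceptor, without a measurable shift in the number. Nothing measured here explains why the number holds.

Because both the substituent and its place on the phenyl ring differ, this one step cannot separate the two; 3-fluorophenyl or 2-aminophenyl would do so. The compounds shown also leave open how a larger change would read here, such as a carboxylic acid on that phenyl ring or a longer chain in its place.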